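The source may hold more compounds than are shown below. What is called first, only, known or untested is meant among the compounds shown, and "the series" means these compounds.

Going by the values given here, the three compounds measured so far share a common core and differ in the groups attached to it. In an in vitro functional assay on cells for agonist activity at Bombesin receptor subtype-3 (Mus musculus), read by luminescence and calcium flux (a higher number here means that more compound is needed for the effect, a lower number that less compound is needed), compound 1 `CCCCc1cnc(C(C)Cc2ccc(-c3ccccc3C(=O)O)cc2)[nH]1` gives 184 nM, and compound 3 `CCCCc1cnc(C(CC)Cc2ccc(-c3ccccc3C(=O)O)cc2)[nH]1` gives 340 nM; between them lies the step of a 1.8-fold higher number from compound 1 to compound 3 (0.27 log units; within the scatter). Compound 2 `O=C(O)c1ccccc1-c1ccc(CCc2ncc(Cc3cccc(F)c3)[nH]2)cc1` gives 7.9 nM in this assay, the lowest of the three numbers, with compound 1 nearest and compound 3 furthest, both beyond the scatter. Compound 4 `Cc1ccc(Cc2cnc(CCc3ccc(-c4ccccc4C(=O)O)cc3)[nH]2)cc1` has not yet been measured; it differs from compound 2 by 4-methylphenyl in place of 3-fluorophenyl on a saturated chain carbon bound to an aromatic carbon. Among the compounds with values here, none of the measured steps alters the group at this position, so the three compounds offer no direct guide; the only measured step, a 1.8-fold higher number from compound 1 to compound 3 (0.27 log units; within the scatter), concerns another place on the chain and stays within the scatter. The expected step is a 2.0-fold higher number from compound 2 to compound 4 (0.31 log units; beyond the scatter), a change near the edge of the scatter and more likely toward a higher number than a lower one. Compound 4 is therefore estimated at 16 nM in this assay, within a range from 4 nM to 65 nM.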

Compound 4, half-maximal effective concentration: 162 nM
The estimate for compound 4 lay 10-fold (1.01 log units) below the measured number, and the stated range ends below it.
By their numbers in this assay, from the lowest: compound 2; then compounds 4, 1 and 3 (each within the scatter of the next, the first and the last beyond it).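

In this assay, going by these compounds alone, the group on the saturated chain carbon bound to an aromatic carbon proves decisive: 4-methylphenyl in place of 3-fluorophenyl gives a 21-fold higher number from compound 2 to compound 4 (1.31 log units; beyond the scatter), a large change at a position the earlier compounds did not probe. The two groups have the same number of heavy atoms and each holds one six-membered aromatic ring of carbon only, so those counts do not predict the size of the step. No measurement shown here explains the step.

The change replaces fluorine with methyl and also moves the substituent, so the compounds shown cannot separate these two differences. As far as these compounds go, whether the loss comes from the new substituent or its new location remains open, and 3-methylphenyl or 4-fluorophenyl at this place would distinguish between them.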